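Trading 3-chloro-4-fluorophenyl for plain phenyl

The source may hold more compounds than are shown below. What is called first, only, known or untested is meant among the compounds shown, and "the series" means these compounds.

Four compounds share one core and differ only in the group on a carbonyl carbon: compound 1 `CC(C)NC(=O)[C@H]1CC[C@@H](n2/c(=N/C(=O)c3ccncc3)[nH]c3ccc(CN4CCC(C(C)(C)O)CC4)cc32)CC1`, compound 2 `CC(C)NC(=O)[C@H]1CC[C@@H](n2/c(=N/C(=O)c3cc(F)cc(C#N)c3)[nH]c3ccc(CN4CCC(C(C)(C)O)CC4)cc32)CC1`, compound 3 `CC(C)NC(=O)[C@H]1CC[C@@H](n2/c(=N/C(=O)c3ccc(F)c(Cl)c3)[nH]c3ccc(CN4CCC(C(C)(C)O)CC4)cc32)CC1` and the still unmeasured compound 4 `CC(C)NC(=O)[C@H]1CC[C@@H](n2/c(=N/C(=O)c3ccccc3)[nH]c3ccc(CN4CCC(C(C)(C)O)CC4)cc32)CC1`. They are compared in an in vitro ADME assay on microsomes from liver (Rattus norvegicus) for metabolic stability; a lower number here means slower removal, a higher number faster removal of the compound. Here compound 3 gives 44 mL.min-1.g-1 and compound 2 gives 30 mL.min-1.g-1, and a 1.5-fold higher number from compound 2 to compound 3 (0.17 log units; within the scatter) shows that the two cannot be told apart. Compound 1 gives < 14 mL.min-1.g-1, which is a limit of the assay and not a number. Two steps do go beyond the scatter: an at least 2.1-fold higher number from compound 1 to compound 2 (0.33 log units; beyond the scatter) and an at least 3.1-fold higher number from compound 1 to compound 3 (0.49 log units; beyond the scatter). Both replace pyridin-4-yl with a substituted phenyl ring.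

The next change is phenyl in place of 3-chloro-4-fluorophenyl on a carbonyl carbon. For the measured compounds named here, no measured step makes exactly this swap, so the evidence is indirect. Compound 4 keeps a ring of carbon only, as does compound 2 at 30 mL.min-1.g-1, so it is expected to land in the same region of this assay. The expected step is a 1.6-fold lower number from compound 3 to compound 4 (0.20 log units; within the scatter), a slightly lower number that would stay within the scatter. For compound 4 the estimated value is 28 mL.min-1.g-1, with an expected range of 15 mL.min-1.g-1 to 50 mL.min-1.g-1.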

Compound 4, intrinsic clearance in microsomes: 21 mL.min-1.g-1
The estimate for compound 4 lay 1.3-fold (0.12 log units) above the measured number; measured number inside the range.
By their numbers in this assay, from the lowest: compounds 4, 2 and 3 (each within the scatter of the next, the first and the last beyond it). At a limit, below all of these: compound 1.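

In this assay, for the compounds shown here, taking the chlorine and fluorine off the ring on the carbonyl carbon gives a 2.1-fold lower number from compound 3 to compound 4 (0.32 log units; beyond the scatter) as a modest change, and this is the first step between two rings of carbon only that goes beyond the scatter. The plain ring does not separate from the other substituted ring, however: the change gives a 1.4-fold lower number from compound 2 to compound 4 (0.15 log units; within the scatter), so the two cannot be told apart. The earlier gaps between pyridin-4-yl and the substituted rings now have a plain phenyl to compare with, but one end of that comparison stands at a limit and not a number: the limit of < 14 mL.min-1.g-1 in this assay, at which 1 of the 4 values shown sits. Phenyl in place of pyridin-4-yl gives an at least 1.5-fold higher number from compound 1 to compound 4 (0.17 log units; that floor lies within the scatter), so the true size of this step stays open.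

The compounds shown leave open whether chlorine alone or fluorine alone on the phenyl ring would account for the step from compound 3 to compound 4. Also open, going by these compounds, is how a saturated ring such as cyclohexyl, or a short chain such as methyl, would read on this carbonyl carbon.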